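Working notes: methylsulfanyl in place of hydroxy

This account rests on a few compounds, and the source may have more. Where it says the series, first, only, none or still open, it means among the compounds named here.

Measured in a functional assay on DU-145 cells (Homo sapiens) for cytotoxicity; a higher number here means a weaker inhibitor of growth, a lower number a stronger inhibitor of growth:
- compound 1 `COc1ccc(C2=C(c3ccc(SC)cc3)CC3CCCN3C2=O)cc1O`: 6000 nM
- compound 2 `COc1ccc(C2=C(c3ccc(SC)cc3)CC3CCCN3C2=O)cc1Br`: 900 nM
- compound 3 `CSc1ccc(C2=C(c3ccc(O)cc3)C(=O)N3CCCC3C2)cc1`: > 100000 nM

Compound 3 stands at > 100000 nM, which is a limit of this assay and not a number. Compound 4 `CSc1ccc(C2=C(c3ccc(SC)cc3)C(=O)N3CCCC3C2)cc1` carries methylsulfanyl in place of hydroxy on an aromatic carbon, para to a large group: methylsulfanyl in place of hydroxy on an aromatic carbon.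

Among the compounds with values here, no measured step covers this exchange directly. Within the data shown here, the nearest precedent is a 6.7-fold lower number from compound 1 to compound 2 (0.82 log units; beyond the scatter), where bromo replaces hydroxy on an aromatic carbon, a modest step beyond the scatter. The same aryl position also matters: an at least 16-fold higher number from compound 1 to compound 3 (1.22 log units; beyond the scatter) and an at least 110-fold higher number from compound 2 to compound 3 (2.04 log units; beyond the scatter) are both large steps. Compound 4 still lacks the 4-methoxyphenyl unit of compound 1 and compound 2, so a modest drop in the number is expected rather than a full recovery. The expected step is an at least 5.0-fold lower number from compound 3 to compound 4 (0.69 log units; beyond the scatter). For compound 4 the estimated value is 20000 nM, with an expected range of 3000 nM to 100000 nM.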

Compound 4, concentration for 50% growth inhibition: 8000 nM
Compound 4: middle estimate off by 2.5-fold (0.40 log units), on the high side; the range from low to high includes it.
By their numbers in this assay, from the lowest: compound 2; then compounds 1 and 4 (each within the scatter of the next). At a limit, above all of these: compound 3.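

In this assay, compound 3 stands at a limit and not a number: the limit of > 100000 nM in this assay, at which 1 of the 4 values shown sits.

Methylsulfanyl in place of hydroxy on this aromatic carbon, para to a large group, brings the series back to a measured value (an at least 12-fold lower number from compound 3 to compound 4 (1.09 log units; beyond the scatter)), so the hydroxy group at this place is the change tied to the loss of a readable number. With 4-(methylsulfanyl)phenyl on the double-bonded ring carbon, compound 4 cannot be told apart from compound 1 (a 1.3-fold higher number from compound 1 to compound 4 (0.12 log units; within the scatter)), while the 3-bromo-4-methoxyphenyl group of compound 2 still gives the lower number (an 8.9-fold higher number from compound 2 to compound 4 (0.95 log units; beyond the scatter)).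

Open, as far as these compounds go, is whether the recovery needs the sulfur of methylsulfanyl at all, or whether a methyl group or an amine on that aromatic carbon would read the same. Also open, from the compounds shown here alone, is how a longer chain such as ethylsulfanyl would read there.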